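Series notes: exocyclic ring in place of the carbamoylmethyl arm

The compounds below may be only part of what the source reports. "The series", "measured", "known", "first", "only" and "open" are said of these compounds alone.

The set rests on two measured compounds sharing one core. Compound 1 `CC(C)C(Cc1nnc[nH]1)c1ccc(-c2ccc3cccc(F)c3c2)[nH]c1=O` carries a 4H-1,2,4-triazol-3-yl on the side chain; in an assay on CHO cells for displacement of a labelled ligand from prostaglandin E2 receptor EP3 subtype (Homo sapiens), read by radioligand binding (on this read-out higher numbers stand for weaker inhibition and lower numbers for stronger inhibition), compound 1 gives 10 nM. Compound 2 `CC(C)C(CC(N)=O)c1ccc(-c2ccc3cccc(F)c3c2)[nH]c1=O` carries carbamoyl in its place and gives 5 nM. Going by the values given here, the only step recorded, a 2.0-fold lower number from compound 1 to compound 2 (0.30 log units; within the scatter), lies within the scatter, so the two numbers cannot be ordered; compound 2 has the lower number of the pair without standing apart from compound 1.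

Compound 3 `CC(C)C(/C=C1\CCNC1=O)c1ccc(-c2ccc3cccc(F)c3c2)[nH]c1=O` is not yet measured. It differs from compound 2 by a group of 7 heavy atoms (5 carbon, 1 nitrogen, 1 oxygen; one five-membered non-aromatic ring with 1 hetero atom) in place of a group of 4 heavy atoms (2 carbon, 1 nitrogen, 1 oxygen; no ring), on a saturated chain carbon bound to an aromatic carbon and a saturated chain carbon. The change exchanges the carbamoylmethyl for a group of 7 heavy atoms that contains one five-membered non-aromatic ring with 1 hetero atom, keeping 1 hydrogen-bond donor and 1 hydrogen-bond acceptor. Among the compounds with values here, no measured step touches a ring closure at this position; the single step from compound 1 to compound 2 bears on it only in showing that changes at this chain carbon have so far stayed within the scatter. The expected step of a 2.0-fold higher number from compound 2 to compound 3 (0.30 log units; within the scatter) is therefore small, in no firm direction. Compound 3 is estimated at 10 nM, within 2 nM to 50 nM.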

Compound 3, inhibition constant: 2.2 nM
Beside the measured number, compound 3's estimate is 4.5-fold (0.66 log units) above it, and the stated range covers the measured number.
By their numbers in this assay, from the lowest: compound 3; then compounds 2 and 1 (each within the scatter of the next).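

With compound 3, the chain carbon bound to an aromatic carbon and a saturated chain carbon gives its first steps beyond the scatter in this assay: the group with the five-membered non-aromatic ring, in place of carbamoylmethyl, gives a modest change (a 2.3-fold lower number from compound 2 to compound 3 (0.36 log units; beyond the scatter)), whereas the earlier exchange of 4H-1,2,4-triazol-3-yl for carbamoyl could not be ordered. Set against the 4H-1,2,4-triazol-3-yl arm, the same group gives a somewhat larger but still modest step (a 4.5-fold lower number from compound 1 to compound 3 (0.66 log units; beyond the scatter)), which leaves compound 3 as the most potent of the three on this read-out and shows that this position can separate compounds, with the hydrogen-bond donor and acceptor counts unchanged from compound 2 to compound 3. The data shown offer no measured basis for explaining this difference.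

The change brings in the ring, the extra carbon atoms and a further double bond outside aromatic rings all at once, so the compounds shown do not say which of these carries the step. Also open, going by these compounds, is how this position would respond to an amine, a carboxylic acid or a longer chain, and whether the step would hold in any read-out other than this binding measurement.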